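The source may hold more compounds than are shown below. What is called first, only, known or untested is meant among the compounds shown, and "the series" means these compounds.

Compound 1, `CC(C)=CCCN(C)C1CCN(CCCc2c[nH]c3ccc(-n4cnnc4)cc23)CC1`: 24 nM in an assay on CHO cells for displacement of a labelled ligand from 5-hydroxytryptamine receptor 1B (Homo sapiens); a higher number here means a weaker inhibitor, a lower number a stronger inhibitor
Compound 2, `c1ccc2c(c1)CCC2NC1CCN(CCCc2c[nH]c3ccc(-n4cnnc4)cc23)CC1`: 280 nM
Compound 3, `CN(C1CCN(CCCc2c[nH]c3ccc(-n4cnnc4)cc23)CC1)S(=O)(=O)c1ccccc1`: 10 nM

Compound 3 gives the lowest number of the three, set apart from compound 1 by a 2.4-fold lower number from compound 1 to compound 3 (0.38 log units; beyond the scatter) and from compound 2 by a 28-fold lower number from compound 2 to compound 3 (1.45 log units; beyond the scatter). Compound 4, `c1cc(CNC2CCN(CCCc3c[nH]c4ccc(-n5cnnc5)cc34)CC2)co1`, differs from compound 3 in one place: ((furan-3-yl)methyl)amino in place of methyl(phenylsulfonyl)amino on a saturated ring carbon. The incoming group, like that of compound 2, carries one hydrogen-bond donor and a ring on the same saturated ring carbon, and the step of a 28-fold lower number from compound 2 to compound 3 (1.45 log units; beyond the scatter) was large, while a 2.4-fold lower number from compound 1 to compound 3 (0.38 log units; beyond the scatter) was modest. Both point to a higher number for compound 4, though the furan group is new and its exact effect is uncertain. Compound 4 is therefore expected to give 100 nM, in the range 30 nM to 400 nM, an expected step of a 10-fold higher number from compound 3 to compound 4 (1.00 log units; beyond the scatter).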

Compound 4, half-maximal inhibitory concentration: 78 nM
For compound 4 the middle estimate is 1.3-fold (0.11 log units) above the measured one; low and high end bracket the measured number.
By their numbers in this assay, from the lowest: compound 3; then compound 1; then compound 4; then compound 2.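

Among these compounds, with a 3.6-fold lower number from compound 2 to compound 4 (0.56 log units; beyond the scatter) as the only change, the group on the amine nitrogen clearly matters even when that nitrogen keeps its hydrogen. Yet ((furan-3-yl)methyl)amino still falls short of the two groups without that hydrogen, with a 7.8-fold higher number from compound 3 to compound 4 (0.89 log units; beyond the scatter) and a 3.3-fold higher number from compound 1 to compound 4 (0.51 log units; beyond the scatter) on the same saturated ring carbon. Among these four, compound 2 and compound 4, which carry a hydrogen-bond donor in this group, give the two higher numbers.

Going by these compounds, whether that hydrogen or the attached ring sets these numbers stays open, and a methyl((furan-3-yl)methyl)amino group on this carbon would separate the two. Nothing shown explains these steps.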